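Removing the Nitro Group from Compound 2

A few compounds are considered here, and "the series" means these few. Any claim that something is new, unique, unknown or untested is made for them only; others in the source may bear on it.

Compound 1 `Cc1ccc(Nc2nnc(Nc3nc(-c4ccc([N+](=O)[O-])cc4)cs3)s2)cc1` gives 100 mg/kg in a functional assay on the whole organism (strain albino) with Mus musculus as the target, in the maximal electroshock model, with a stated time of 4 h; a lower number here means that less compound is needed, a higher number that more compound is needed for the effect.
Compound 2 `COc1ccccc1Nc1nnc(Nc2nc(-c3ccc([N+](=O)[O-])cc3)cs2)s1` gives 300 mg/kg in this assay.

Within the data shown here, of the two numbers in this assay, compound 2 stands at the highest; the nearest is compound 1, and the only measured step is a 3.0-fold higher number from compound 1 to compound 2 (0.48 log units; beyond the scatter). Compound 3 `COc1ccccc1Nc1nnc(Nc2nc(-c3ccccc3)cs2)s1` differs from compound 2 by hydrogen in place of nitro on an aromatic carbon. Among the measured compounds shown here, the measured step alters the aryl amine rather than the nitro group, so no measured step bears on this change. The expected step is therefore none beyond the scatter, no change at the digits printed from compound 2 to compound 3 (within the scatter). Compound 3 is estimated at 300 mg/kg, with a range from 100 mg/kg to 1000 mg/kg.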

Compound 3, minimum effective dose: 300 mg/kg
Beside the measured number, compound 3's estimate shows no gap at the digits printed; the range from low to high includes it.
By their numbers in this assay, from the lowest: compound 1; then compounds 2 and 3 (each within the scatter of the next).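

Exchanging 4-nitrophenyl for phenyl gives no change at the digits printed from compound 2 to compound 3 (within the scatter) in this assay. Among these compounds, the earlier step spoke only to the aryl amine; this is the first reading at the other aryl group, and with the 2-methoxyphenyl amine in place, the nitro group can leave without a shift beyond the scatter. Nothing at hand explains this result. As far as these compounds go, it remains open whether an amine or a carboxylic acid at this position would move the number, and whether the 4-methylphenyl amine of compound 1 would tolerate the same exchange.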